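Trimming an ethyl to a methyl on the shared core

The source may hold more compounds than are shown below. What is called first, only, known or untested is meant among the compounds shown, and "the series" means these compounds.

Measured so far:
Compound 1 `CCc1ccccc1-n1nc(C)c2c1NC(=O)[C@H](C)S[C@@H]2c1ccc(Oc2ccccc2)cc1`: 1100 nM
Compound 2 `Cc1ccccc1-n1nc(C)c2c1NC(=O)[C@H](C)S[C@@H]2c1ccc(-c2ccsc2)cc1`: 1400 nM
Compound 3 `Cc1ccccc1-n1nc(C)c2c1NC(=O)[C@H](C)S[C@@H]2c1ccc(-c2ccc(C(=O)O)cc2)cc1`: "not active" (no number reported)

In an assay on isolated protein for agonist activity at Bile acid receptor (Homo sapiens), read by AlphaScreen, with a stated time of 30 min (a lower number here means that less compound is needed, a higher number that more compound is needed for the effect), compound 1 gives 1100 nM, the lowest of the two numbers recorded. Compound 2 gives 1400 nM, which lies within the scatter of compound 1, so the two cannot be ranked. Compound 3 gives "not active" (no number reported), with no number reported.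

Compound 4 `Cc1ccccc1-n1nc(C)c2c1NC(=O)[C@H](C)S[C@@H]2c1ccc(Oc2ccccc2)cc1` has not yet been measured. It differs from compound 1 in one place: hydrogen in place of methyl on a saturated chain carbon bound to an aromatic carbon. For the measured compounds named here, no measured pair shows this change on its own, so no size can be read off. The change is small, and a step of no more than the scatter is expected in this assay, in either direction. Compound 4 is therefore expected to give about 1300 nM, between 550 nM and 3200 nM, a step of a 1.2-fold higher number from compound 1 to compound 4 (0.07 log units; within the scatter) estimated.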

Compound 4, half-maximal effective concentration: 1300 nM
The estimate for compound 4 equals the measured number at the digits printed, within the range that was stated.
By their numbers in this assay, from the lowest: compounds 1, 4 and 2 (each within the scatter of the next).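

In this assay, the 2-ethylphenyl and 2-methylphenyl compounds cannot be told apart, with a 1.2-fold higher number from compound 1 to compound 4 (0.07 log units; within the scatter), so removing that one carbon costs nothing measurable here. Putting phenoxy in place of thiophen-3-yl on an aromatic carbon also gives a step within the scatter, a 1.1-fold lower number from compound 2 to compound 4 (0.03 log units; within the scatter). No measurement here offers a reason for either result.

Still open, going by these compounds, is whether a longer chain such as propyl, or a methoxy group, would give a clear step at this place.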